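Lengthening the side chain: tolerated concentration in fly cells

This account rests on a few compounds, and the source may have more. Where it says the series, first, only, none or still open, it means among the compounds named here.

The measured compounds and their values:

Compound 1, `CCCCCC(=O)c1c(O)c(Cl)c(O)c(Cl)c1O`: in an ADME assay on the whole organism (strain S2) for cytotoxicity, with Drosophila as the target, read by WST assay (a lower number here means that less compound is tolerated, a higher number that more compound is tolerated), compound 1 gives 102000 nM.
Compound 2, `CCCC(=O)c1c(O)c(Cl)c(O)c(Cl)c1O`: in this assay compound 2 gives > 100000 nM; this is a limit of the assay, not a number, as the limit of > 100000 nM in this assay, at which 1 of the 3 values shown sits, records.
Compound 3, `CCCCC(=O)c1c(OC)c(Cl)c(OC)c(Cl)c1OC`: in this assay compound 3 gives 149000 nM.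

Compound 1 and compound 2 share a core and differ only in the side chain. The change is ethyl in place of hydrogen on a saturated chain carbon, three bonds along the chain from a carbonyl carbon. Because compound 2 sits at a limit, the size of this step is not readable: a step that the limit leaves unreadable from compound 2 to compound 1. Compound 3 carries a differently substituted core; how it differs from compound 2 is not broken down here. The values of compound 3 and compound 1 lie within the usual scatter of each other, so no order between them can be claimed.

The next compound, compound 4, `CCCCCCC(=O)c1c(OC)c(Cl)c(OC)c(Cl)c1OC`, keeps the core of compound 3 and carries a longer chain. The change is ethyl in place of hydrogen on a saturated chain carbon, four bonds along the chain from a carbonyl carbon. It is the same kind of change as that from compound 2 to compound 1, but the place differs: there the ethyl enters three bonds along the chain from a carbonyl carbon, here four bonds along the chain from a carbonyl carbon.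

Within this small set, adding two chain carbons has not moved the tolerated concentration in a readable way, so for compound 4 a step near flat is expected, a 1.1-fold lower number from compound 3 to compound 4 (0.03 log units; within the scatter), resting on compound 1 at 102000 nM and compound 3 at 149000 nM. For compound 4 in this assay the estimated value is 140000 nM, expected to fall between 70000 nM and 280000 nM.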

Compound 4, half-maximal cytotoxic concentration: 140000 nM
Estimate against measurement, compound 4: no gap at the digits printed; low and high end bracket the measured number.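

In this assay, placing ethyl in place of hydrogen on a saturated chain carbon, four bonds along the chain from a carbonyl carbon, on the core of compound 3 gives a 1.1-fold lower number from compound 3 to compound 4 (0.03 log units; within the scatter), so on this core the longer chain produces no readable difference. The same kind of change on the other core, where it stands three bonds along the chain from a carbonyl carbon, cannot be read as a step, because compound 2 is recorded only as a limit of the assay and not as a number: the limit of > 100000 nM in this assay, at which 1 of the 4 values shown sits. The series therefore offers one readable step on one core, which does not show that the change carries over to the other core, and does not show that it behaves differently there either.

The compounds shown leave open how the two cores compare when the chain is held the same, as each pair here differs in the core and the chain together or only in the chain. They also leave open how this assay would read for a longer chain than that of compound 4, or for a chain ending in an amine or a carboxylic acid.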